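From compound 2 to compound 3: a new side chain

The compounds below may be only part of what the source reports. "The series", "measured", "known", "first", "only" and "open" are said of these compounds alone.

In a functional assay on MDA-MB-231 cells (Homo sapiens) for antiproliferative activity, read by MTT assay, with a stated time of 24 h (on this read-out higher numbers stand for weaker inhibition and lower numbers for stronger inhibition), compound 1 `CCCCc1oc2ccccc2c1C(=O)c1ccc(OCC(N)=O)cc1` reads > 50000 nM as a limit of the assay and not as a number. Going by the values given here, compound 2 `CCCCc1oc2ccccc2c1C(=O)c1ccc(OCC(=O)N[C@H](C)c2ccccc2)cc1` gives 39000 nM as the only true number so far. Compound 3 `CCCCc1oc2ccccc2c1C(=O)c1ccc(OCCCC(=O)N2CCCC2)cc1` is not yet measured. It carries 2-((pyrrolidin-1-yl)carbonyl)ethyl in place of (1-phenylethyl)carbamoyl on a saturated chain carbon bound to an oxygen on an aromatic ring. Among the compounds with values here, the one measured step that bears on this (an at least 1.2-fold lower number from compound 1 to compound 2 (0.10 log units; that floor lies within the scatter)) put 1-phenylethyl in place of hydrogen on an amide-type nitrogen, and its floor lies within the scatter. With only that to go on, no shift beyond the scatter is expected in this assay for this change. The step expected (a 1.0-fold higher number from compound 2 to compound 3 (0.01 log units; within the scatter)) is therefore small. Compound 3 is estimated at 40000 nM with an expected range of 15000 nM to 100000 nM and could also return only a limit.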

Compound 3, half-maximal inhibitory concentration: 48700 nM
For compound 3 the middle estimate is 1.2-fold (0.09 log units) below the measured one; the range from low to high includes it.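

In this assay, the new side chain gives a 1.2-fold higher number from compound 2 to compound 3 (0.10 log units; within the scatter): at this place, the six-membered aromatic ring, the defined stereocentre and the hydrogen-bond donor of (1-phenylethyl)carbamoyl can all go together with no shift beyond the scatter. The comparison with the plain carbamoyl gives only a floor, an at least 1.0-fold lower number from compound 1 to compound 3 (0.01 log units; that floor lies within the scatter), since the value on that side is a limit of the assay and not a number. Both readable values also lie close to the top of what this assay reports: the limit of > 50000 nM in this assay, at which 1 of the 3 values shown sits.

The compounds shown leave open whether any group at this place can lower the number beyond the scatter, such as a terminal amine or a carboxylic acid. Compound 3 also changes the chain and the amide at once, leaving their separate contributions unresolved.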